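Plasma half-life of a bis-ester core: nitrooxymethyl variant

The compounds below may be only part of what the source reports. "The series", "measured", "known", "first", "only" and "open" are said of these compounds alone.

Measured so far:
compound 1 `CC(=O)Oc1ccccc1C(=O)O[C@H]1CO[C@H]2[C@@H]1OC[C@H]2OC(=O)c1cccc(O)c1` gives 0.015 h
compound 2 `CC(=O)Oc1ccccc1C(=O)O[C@H]1CO[C@H]2[C@@H]1OC[C@H]2OC(=O)c1ccc(-c2ccccc2)cc1` gives > 0.333 h

Both were read in an ADME assay on a cell-free system (plasma, Homo sapiens) for metabolic stability, with Plasma (Rattus norvegicus) as the target, read by HPLC, at pH 7.4; a higher number here means that the compound lasts longer, a lower number that the compound disappears faster. For compound 2 the value is a limit, not a number (the limit of > 0.333 h in this assay, at which 1 of the 2 values shown sits). Compound 2 thus stands at the top of what has been seen. Compound 3 `CC(=O)Oc1ccccc1C(=O)O[C@H]1CO[C@H]2[C@@H]1OC[C@H]2OC(=O)c1ccc(CO[N+](=O)[O-])cc1` differs from compound 2 by (nitrooxy)methyl in place of phenyl on an aromatic carbon. For the measured compounds named here, the only measured step, an at least 22-fold higher number from compound 1 to compound 2 (1.34 log units; beyond the scatter), concerns a different swap at the same carbonyl-bearing ring and shows that changes there can move the half-life a great deal. A downward step an at least 3.3-fold lower number from compound 2 to compound 3 (0.52 log units; beyond the scatter) is expected for compound 3. Compound 3 is estimated at 0.1 h, between 0.02 h and 0.45 h.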

Compound 3, half-life: 0.04 h
Compound 3: middle estimate off by 2.5-fold (0.40 log units), on the high side, within the range that was stated.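

In this assay, (nitrooxy)methyl in place of phenyl gives an at least 8.3-fold lower number from compound 2 to compound 3 (0.92 log units; beyond the scatter), so the long half-life seen with 4-phenylphenyl does not carry over to every group at this aromatic carbon. The 4-((nitrooxy)methyl)phenyl group still keeps part of the gain over 3-hydroxyphenyl, with a 2.7-fold higher number from compound 1 to compound 3 (0.43 log units; beyond the scatter). The figure for compound 2 is a limit, not a number: the limit of > 0.333 h in this assay, at which 1 of the 3 values shown sits.

The compounds shown leave open whether the drop follows from the nitrooxy group itself or from the loss of the phenyl ring, which a hydroxymethyl or plain methyl group at that carbon would separate. They also do not tell which of the two ester bonds breaks first.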